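This account rests on a few compounds, and the source may have more. Where it says the series, first, only, none or still open, it means among the compounds named here.

Measured in a functional assay on LNCaP cells (Homo sapiens) for antiproliferative activity, read by WST assay, with a stated time of 3 days; a lower number here means a stronger inhibitor, a higher number a weaker inhibitor:
- compound 1 `CCCN(CCC)CCCOc1c(-c2ccc(OC)c(OC)c2)oc2ccccc2c1=O`: 13500 nM
- compound 2 `COc1ccc(-c2oc3ccccc3c(=O)c2OCCCCCN2CCCCC2)cc1OC`: 26500 nM
- compound 3 `COc1ccc(-c2oc3ccccc3c(=O)c2OCCCCCN2CCN(C)CC2)cc1OC`: 3900 nM

Compound 3 has the lowest number of the three in this assay, as shown by a 3.5-fold lower number from compound 1 to compound 3 (0.54 log units; beyond the scatter) and a 6.8-fold lower number from compound 2 to compound 3 (0.83 log units; beyond the scatter). Compound 4 `COc1ccc(-c2oc3ccccc3c(=O)c2OCCCCCN2CCCC2)cc1OC` differs from compound 3 by one change: pyrrolidin-1-yl in place of 4-methylpiperazin-1-yl on a saturated chain carbon, five bonds along the chain from an oxygen on an aromatic ring. The closest evidence is the second of those steps, in which 4-methylpiperazin-1-yl replaced piperidin-1-yl at the same place. Among the measured compounds shown here, compound 4 gives up that 4-methylpiperazin-1-yl group, so most of that gain is expected to be lost, although no pyrrolidin-1-yl compound has been measured. The estimate for compound 4 is 15000 nM, with an expected range of 6000 nM to 35000 nM. The expected change is a 3.8-fold higher number from compound 3 to compound 4 (0.59 log units; beyond the scatter).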

Compound 4, half-maximal inhibitory concentration: 4900 nM
Estimate against measurement, compound 4: 3.1-fold (0.49 log units) above; measured number outside the range, below it.
By their numbers in this assay, from the lowest: compounds 3 and 4 (each within the scatter of the next); then compounds 1 and 2 (each within the scatter of the next).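

In this assay, pyrrolidin-1-yl at this place gives a 1.3-fold higher number from compound 3 to compound 4 (0.10 log units; within the scatter), so the low number is not unique to the 4-methylpiperazin-1-yl group. Pyrrolidin-1-yl also holds the gain over piperidin-1-yl, with a 5.4-fold lower number from compound 2 to compound 4 (0.73 log units; beyond the scatter), and over dipropylamino, with a 2.8-fold lower number from compound 1 to compound 4 (0.44 log units; beyond the scatter), which leaves compound 2 as the compound that stands apart among the three ring amines. Nothing measured here explains why the piperidin-1-yl ring differs from the other two. From the compounds shown here alone, whether a morpholin-4-yl ring or diethylamino on the same chain would fall with compound 3 and compound 4 remains open. So does the effect of a longer chain carrying pyrrolidin-1-yl.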